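Benzylamino in place of aryl at the carbonyl

The source may report more compounds than this note shows. Statements on the series, on what has been measured and on what is new or still open speak of the compounds shown alone.

Measured so far:
compound 1, `Cc1ccc(C)c(C(=O)OC(CCN(C)C)c2ccc(Cl)cc2)c1`: 1860 nM
compound 2, `Cc1cc(Br)ccc1C(=O)OC(CCN(C)C)c1ccc(Cl)cc1`: 1070 nM

In an assay on NIH3T3 cells with Urotensin-2 receptor (Homo sapiens) as the target (a higher number here means that more compound is needed for the effect, a lower number that less compound is needed), compound 1 gives 1860 nM and compound 2 gives 1070 nM. Among the compounds with values here, compound 2 holds the smaller of the two numbers, but the only step, a 1.7-fold lower number from compound 1 to compound 2 (0.24 log units; within the scatter), is within the scatter, so the two compounds are not separated.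

Compound 3, `CN(C)CCC(OC(=O)NCc1ccccc1)c1ccc(Cl)cc1`, is not yet measured. Its change from compound 2: benzylamino in place of 4-bromo-2-methylphenyl on a carbonyl carbon. Within the data shown here, no measured step touches the carbonyl-bound group in this way; a 1.7-fold lower number from compound 1 to compound 2 (0.24 log units; within the scatter) only exchanged substituents on the same aromatic ring and stayed within the scatter. Nothing here bears on replacing the aryl by benzylamino, so no direction is supported and the range must be wide. Near compound 2, the estimate for compound 3 is 2000 nM, with a range from 500 nM to 8000 nM. That corresponds to an expected step of a 1.9-fold higher number from compound 2 to compound 3 (0.27 log units; within the scatter).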

Compound 3, half-maximal effective concentration: 2140 nM
Estimate against measurement, compound 3: 1.1-fold (0.03 log units) below; measured number inside the range.
By their numbers in this assay, from the lowest: compounds 2, 1 and 3 (each within the scatter of the next).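

In this assay, the exchange of an aryl group for benzylamino on the carbonyl carbon gives a 2.0-fold higher number from compound 2 to compound 3 (0.30 log units; within the scatter) and a 1.2-fold higher number from compound 1 to compound 3 (0.06 log units; within the scatter) and so leaves all three compounds unseparated. The earlier step varied only the substituents on one aromatic ring, whereas here the aryl group itself leaves and benzylamino enters with its hydrogen-bond donor, and still no separation appears. No supporting measurement bears on this result.

On these data alone, whether any group on this carbonyl carbon can give a step beyond the scatter remains open, for instance phenethylamino, with its longer chain, or a plain dimethylamino group. Also open, as far as these compounds go, is whether the amide hydrogen of benzylamino has any bearing on the number, which a benzyl(methyl)amino group would address.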